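The source may report more compounds than this note shows. Statements on the series, on what has been measured and on what is new or still open speak of the compounds shown alone.

In an ADME assay on HEL cells (Homo sapiens) for cytotoxicity, read by microscopy (on this read-out higher numbers stand for lower toxicity in this test and lower numbers for higher toxicity in this test), compound 1 `O=C(O)c1ccc(OCCCCCn2ccc(=O)[nH]c2=O)cc1` reaches only a limit of the measurement, giving > 100000 nM. Compound 2 `Cc1cc(C)cc(OCCCCCn2ccc(=O)[nH]c2=O)c1` likewise sits at a limit in this assay, with > 100000 nM. Compound 3 `Cc1ccccc1OCCCCCn1ccc(=O)[nH]c1=O` stands at the same limit in this assay, where it gives > 100000 nM, so no number is known for it, only a bound. the limit of > 100000 nM in this assay, at which 3 of the 3 values shown sit, describes where all three measured compounds sit. Compound 4 `Cc1cccc(OCCCCCn2ccc(=O)[nH]c2=O)c1` differs from compound 3 by 3-methylphenyl in place of 2-methylphenyl on an oxygen on a saturated carbon. For the measured compounds named here, since no step between measured compounds is available here, the step expected in this assay, a number no higher from compound 3 to compound 4 (the limit leaves the size open), is none beyond the usual scatter. Compound 4 is therefore estimated to give about 100000 nM, between 50000 nM and 300000 nM, most likely again reported only as a limit.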

Compound 4, minimum cytotoxic concentration: > 100000 nM
Compound 4: only a limit was reported; the forecaster's own chance of this, stated with the estimate: 90%; the middle value sits exactly at the limit.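

The steps from compound 3 and from compound 2 to compound 4 cannot be read, as every value is only a limit: the limit of > 100000 nM in this assay, at which 4 of the 4 values shown sit.

The compounds shown leave open at what concentration any of them becomes cytotoxic in this assay and whether their aryl groups differ at all.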